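The source may hold more compounds than are shown below. What is called first, only, known or untested is meant among the compounds shown, and "the series" means these compounds.

Compound 2 `O=C(CCl)Nc1cccc(Cn2nc(-c3ccc(Oc4ccccc4)cc3)cc2CO)c1` is the anchor of this small set. In a functional assay on JeKo-1 cells (Homo sapiens) for inhibition, read by luminescence and CellTiter-Glo, with a stated time of 72 h (on this read-out lower numbers stand for stronger inhibition and higher numbers for weaker inhibition), compound 2 gives 400 nM. Compound 1 `C=CC(=O)Nc1cccc(Cn2nc(-c3ccc(Oc4ccccc4)cc3)cc2CO)c1` differs from it by vinyl in place of chloromethyl on a carbonyl carbon; in this assay compound 1 gives 5200 nM, and a 13-fold higher number from compound 2 to compound 1 (1.11 log units; beyond the scatter). Compound 3 `O=C(CCl)Nc1cccc(Cn2nc(-c3ccc(Oc4ccccc4)cc3)cc2C(=O)O)c1` has a different core, the change being (carboxy in place of hydroxymethyl on an aromatic carbon); in this assay compound 3 gives 6300 nM, so that a 16-fold higher number from compound 2 to compound 3 (1.20 log units; beyond the scatter). Compound 4 `C=CC(=O)Nc1cccc(Cn2nc(-c3ccc(Oc4ccccc4)cc3)cc2C(=O)O)c1` has not yet been measured. Among the compounds with values here, it differs from compound 3 by vinyl in place of chloromethyl on a carbonyl carbon, the same change and the same place as the one from compound 2 to compound 1, now carried on the core of compound 3. Because a 13-fold higher number from compound 2 to compound 1 (1.11 log units; beyond the scatter) was a large step, compound 4 is expected to move by a comparable amount, a 7.9-fold higher number from compound 3 to compound 4 (0.90 log units; beyond the scatter), resting on that single precedent. Compound 4 is therefore estimated at 50000 nM, between 12000 nM and 150000 nM, with a fair chance that only a limit is returned.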

Compound 4, half-maximal inhibitory concentration: > 60000 nM
Compound 4: a limit, no number; the forecaster's own chance of this, stated with the estimate: 40%; middle value at least 1.2-fold (0.07 log units) away from the limit.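

In this assay compound 4 returns only a limit of > 60000 nM and not a number. Vinyl in place of chloromethyl on a carbonyl carbon moves the number the same way on the core of compound 3, with an at least 9.5-fold higher number from compound 3 to compound 4 (0.97 log units; beyond the scatter), so the direction carries over between these two cores, but whether the size does stays unsettled: the same change on two cores in this assay, a 13-fold higher number (1.11 log units; beyond the scatter) from compound 2 to compound 1 and an at least 9.5-fold higher number (0.97 log units; beyond the scatter) from compound 3 to compound 4; the limit leaves it open whether they differ. Read from the other side, carboxy in place of hydroxymethyl on an aromatic carbon gives an at least 11-fold higher number from compound 1 to compound 4 (1.06 log units; beyond the scatter), and again only the direction is shown: the same change on two cores in this assay, a 16-fold higher number (1.20 log units; beyond the scatter) from compound 2 to compound 3 and an at least 11-fold higher number (1.06 log units; beyond the scatter) from compound 1 to compound 4; the limit leaves it open whether they differ.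

The compounds shown leave open how far compound 4 lies past its limit. They also leave open whether bromomethyl on the carbonyl carbon, or an amine in place of the hydroxymethyl, would follow the same course.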